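From Ethyl to Fluoro on the Sulfonamide Nitrogen's Ring

This account rests on a few compounds, and the source may have more. Where it says the series, first, only, none or still open, it means among the compounds named here.

Four compounds share one core and differ only in the aromatic group on the sulfonamide nitrogen. Within the data shown here, in a functional assay on DU-145 cells (Homo sapiens) for inhibition, read by CCK-8 assay, with a stated time of 72 h (on this read-out higher numbers stand for weaker inhibition and lower numbers for stronger inhibition), compound 1 (`Cc1cccc(NS(=O)(=O)c2cccc(CCCCCCNC(=O)/C=C/c3cccnc3)c2)c1`) gives 41.7 nM and compound 2 (`Cc1ccc(C)c(NS(=O)(=O)c2cccc(CCCCCCNC(=O)/C=C/c3cccnc3)c2)c1`) gives 7.48 nM as the lowest number so far. Compound 3 (`CCc1ccc(NS(=O)(=O)c2cccc(CCCCCCNC(=O)/C=C/c3cccnc3)c2)cc1`) gives 40.1 nM in this assay and so sits level with compound 1, well apart from compound 2.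

Compound 4 (`O=C(/C=C/c1cccnc1)NCCCCCCc1cccc(S(=O)(=O)Nc2ccc(F)cc2)c1`) has not yet been measured. It differs from compound 3 by fluoro in place of ethyl on an aromatic carbon, para to a large group (fluoro in place of ethyl on an aromatic carbon). Among the measured compounds shown here, no measured step places a fluoro, so the evidence is indirect. The closest guide is a 1.0-fold lower number from compound 1 to compound 3 (0.02 log units; within the scatter) for 4-ethylphenyl in place of 3-methylphenyl, a swap that lies within the scatter. Only the 2,5-dimethylphenyl group of compound 2 stands apart, with a 5.6-fold lower number from compound 1 to compound 2 (0.75 log units; beyond the scatter) and a 5.4-fold higher number from compound 2 to compound 3 (0.73 log units; beyond the scatter) as the modest steps around it. Compound 4 carries one group on that ring, as compounds 1 and 3 do, so no step beyond the scatter is expected. The expected change is a 1.1-fold lower number from compound 3 to compound 4 (0.06 log units; within the scatter) and no more. In this assay compound 4 is estimated at 35 nM within an expected range from 12 nM to 100 nM.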

Compound 4, half-maximal inhibitory concentration: 10.6 nM
Estimate against measurement, compound 4: 3.3-fold (0.52 log units) above; measured number outside the range, below it.
By their numbers in this assay, from the lowest: compounds 2 and 4 (each within the scatter of the next); then compounds 3 and 1 (each within the scatter of the next).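

In this assay, the ring on the sulfonamide nitrogen turns out to be sensitive to which single group it carries: fluoro in place of ethyl, on an aromatic carbon para to a large group, gives a 3.8-fold lower number from compound 3 to compound 4 (0.58 log units; beyond the scatter) and the swap of 3-methylphenyl for 4-fluorophenyl gives a 3.9-fold lower number from compound 1 to compound 4 (0.59 log units; beyond the scatter) as well. Among these compounds, the earlier compounds could not show this, since the only swap between two rings with one group each, from compound 1 to compound 3, stayed within the scatter, and only the 2,5-dimethylphenyl ring of compound 2 stood apart. That ring no longer stands alone, for the change to 4-fluorophenyl gives a 1.4-fold higher number from compound 2 to compound 4 (0.15 log units; within the scatter) and so a ring with one fluoro sits level with a ring with two methyl groups.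

From the compounds shown here alone, whether a chloro, a methoxy or an amine at the same place would read like fluoro or like ethyl stays open, as does whether a second fluoro on the ring would move the number at all. Nothing measured on these compounds accounts for the difference between fluoro and ethyl at this place.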